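Leucyl sulfamoyl benzamides: aryl-to-methyl step on the pyrimidine

The compounds below may be only part of what the source reports. "The series", "measured", "known", "first", "only" and "open" are said of these compounds alone.

Measured so far in an assay on isolated protein for inhibition of leucine--tRNA ligase, cytoplasmic (Homo sapiens); on this read-out higher numbers stand for weaker inhibition and lower numbers for stronger inhibition: compound 1 `CC(C)C[C@H](N)C(=O)NS(=O)(=O)c1cccc(-c2cccc(N)n2)c1` gives 850 nM; compound 2 `Cc1cc(-c2cccc(S(=O)(=O)NC(=O)[C@@H](N)CC(C)C)c2)ncn1` gives 2000 nM; compound 3 `CC(C)C[C@H](N)C(=O)NS(=O)(=O)c1cccc(-c2cc(-c3ccccc3)nc(N)n2)c1` gives 33 nM.

Compound 3 stands lowest of the three numbers; the values of compound 1 and compound 2 both lie well above it, beyond the scatter, so compound 3 is the most potent of the set. Compound 4 `Cc1cc(-c2cccc(S(=O)(=O)NC(=O)[C@@H](N)CC(C)C)c2)nc(N)n1` differs from it by methyl in place of phenyl on an aromatic carbon. Going by the values given here, no measured step removes a phenyl from this position; the only step on record, a 2.4-fold higher number from compound 1 to compound 2 (0.37 log units; beyond the scatter), concerns a different exchange of the heteroaryl ring and was modest. Compound 2, carrying methyl but no amino group, sits far above compound 3, so a loss beyond the scatter is expected for compound 4, a 9.1-fold higher number from compound 3 to compound 4 (0.96 log units; beyond the scatter). For compound 4 the expected value in this assay is 300 nM, within 80 nM to 1200 nM.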

Compound 4, half-maximal inhibitory concentration: 160 nM
Estimate against measurement, compound 4: 1.9-fold (0.27 log units) above; the measured number falls inside the stated range.
By their numbers in this assay, from the lowest: compound 3; then compound 4; then compound 1; then compound 2.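

In this assay, amino in place of hydrogen on an aromatic carbon gives a 13-fold lower number from compound 2 to compound 4 (1.10 log units; beyond the scatter), a large step, whereas methyl in place of phenyl gives a 4.8-fold higher number from compound 3 to compound 4 (0.69 log units; beyond the scatter), a modest one. With 2-amino-6-methylpyrimidin-4-yl in place of 6-aminopyridin-2-yl, the series shows a 5.3-fold lower number from compound 1 to compound 4 (0.73 log units; beyond the scatter), so a number below that of compound 1 does not require the phenyl. Nothing measured accounts for these steps. Open: whether ethyl, cyclopropyl or a longer chain in place of methyl would come closer to compound 3.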